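This account rests on a few compounds, and the source may have more. Where it says the series, first, only, none or still open, it means among the compounds named here.

Measured so far:
- Compound 1, `O=C(CCc1nnc(-c2ccccc2)o1)c1ccccc1`: 29.4% in a functional assay on the whole organism (strain Wistar) for inhibition, with Rattus norvegicus as the target, with stated times of 30 min and 3 h, at a dose of 20 mg/kg by the oral route; on this read-out higher numbers stand for more inhibition at the one dose given (going by the name of the read-out) and lower numbers for less inhibition
- Compound 2, `O=C(CCc1nnc(-c2ccccc2Cl)o1)c1ccccc1`: 35.8%

Going by the values given here, of these two numbers, compound 2 holds the top one, yet the only measured step, a number 6.4 percentage points higher from compound 1 to compound 2 (within the scatter), lies within the scatter, so the two compounds cannot be told apart on this evidence. Compound 3, `Cc1ccc(C(=O)CCc2nnc(-c3ccccc3Cl)o2)c(C)c1`, is the next compound to be tested. It differs from compound 2 in one place: 2,4-dimethylphenyl in place of phenyl on a carbonyl carbon. Among the compounds with values here, no measured step touches that group on the carbonyl carbon; the one step known concerns a different part of the molecule and was itself small. There is therefore nothing in the data that points to a change beyond the scatter. The step from compound 2 to compound 3 is expected to be a number 0.2 percentage points higher from compound 2 to compound 3 (within the scatter). Compound 3 is estimated at 36%, with a range from 15% to 55%.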

Compound 3, a percentage reported as inhibition, in the whole organism at one dose (the size of the read-out at that dose, not a potency): 60.5%
Compound 3: the middle estimate sits 24.5 percentage points below what was measured; measured number outside the range, above it.
By their numbers in this assay, from the lowest: compounds 1 and 2 (each within the scatter of the next); then compound 3.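

Changing the group on the carbonyl carbon from phenyl to 2,4-dimethylphenyl gives a number 24.7 percentage points higher from compound 2 to compound 3 (beyond the scatter) in this assay. Going by these compounds alone, the only earlier step, chloro in place of hydrogen on the other aromatic ring, stayed within the scatter, so this is the first place where a change clearly moves the read-out. This is a difference in inhibition at one dose rather than in potency, and nothing available here accounts for the rise.

As far as these compounds go, the change adds both methyl groups at once, so it remains open whether one methyl group would give a similar number or whether a methoxy group or an amine on that ring would do as well. From the compounds shown here alone, it is also open whether 2,4-dimethylphenyl would raise the number on the core of compound 1, which lacks the chloro group.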